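Benzyl replaces chlorophenyl on a weakly antiproliferative series

The compounds below may be only part of what the source reports. "The series", "measured", "known", "first", "only" and "open" are said of these compounds alone.

Compound 3 `S=C(N/N=C/c1ccc2ccccc2n1)Nc1ccc(Cl)cc1` is one of three close relatives sharing a core that differ only in the aryl group on an amide-type nitrogen. In a functional assay on HL-60 cells (Homo sapiens) for antiproliferative activity, read by sulforhodamine B assay, with a stated time of 72 h (on this read-out lower numbers stand for stronger inhibition and higher numbers for weaker inhibition), compound 3 gives > 100000 nM, which is a limit of the assay rather than a number. Compound 1 `COc1cccc(NC(=S)N/N=C/c2ccc3ccccc3n2)c1` gives 71200 nM in this assay. Compound 2 `Fc1ccccc1NC(=S)N/N=C/c1ccc2ccccc2n1` gives > 100000 nM in this assay, again a limit. The steps from 1 to the two other members are an at least 1.4-fold higher number from compound 1 to compound 2 (0.14 log units; that floor lies within the scatter) and an at least 1.4-fold higher number from compound 1 to compound 3 (0.14 log units; that floor lies within the scatter), and the step between them is a step that the two limits leave unreadable from compound 2 to compound 3, all because of the limit of > 100000 nM in this assay, at which 2 of the 3 values shown sit.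

Compound 4 `S=C(NCc1ccccc1)N/N=C/c1ccc2ccccc2n1` differs from compound 3 by benzyl in place of 4-chlorophenyl on an amide-type nitrogen. For the measured compounds named here, no measured step involves a benzyl group, and the aryl swaps that were measured all bottom out at the limit, so there is nothing to suggest a large move in either direction beyond the scatter. Compound 4 is therefore expected to remain weak in this assay, with an estimated step of an at least 1.1-fold lower number from compound 3 to compound 4 (0.04 log units; that floor lies within the scatter). The estimated value of compound 4 is 90000 nM, within a range from 30000 nM to 250000 nM, and a limit rather than a number is quite possible.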

Compound 4, half-maximal inhibitory concentration: 21900 nM
Beside the measured number, compound 4's estimate is 4.1-fold (0.61 log units) above it, and the stated range ends above it.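

Replacing each aryl group on the amide-type nitrogen by benzyl produces what the swaps among aryl groups could not: a change beyond the scatter in this assay, with an at least 4.5-fold lower number from compound 3 to compound 4 (0.65 log units; beyond the scatter) and an at least 4.5-fold lower number from compound 2 to compound 4 (0.65 log units; beyond the scatter) as well as a 3.3-fold lower number from compound 1 to compound 4 (0.51 log units; beyond the scatter). The steps from compound 2 and compound 3 start from limits and are only floors, and the step from compound 1 alone has a definite size. Compound 4 thus stands as the most active of the four, which shows that this position can move the read-out, though the step with a definite size is modest.

On these data alone, it remains open whether a longer chain such as phenethyl would carry the change further. Also open, as far as these compounds go, is whether a 4-chlorobenzyl group would behave like benzyl or like 4-chlorophenyl.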